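This account rests on a few compounds, and the source may have more. Where it says the series, first, only, none or still open, it means among the compounds named here.

Measured compounds:
compound 1 `O=S(=O)(NCCCNc1nccc(-c2c(-c3cccc(F)c3)nc3sccn23)n1)c1cccc(F)c1`: 13700 nM in a functional assay on A-375 cells (Homo sapiens) for cytotoxicity, read by MTT assay; on this read-out higher numbers stand for weaker inhibition and lower numbers for stronger inhibition
compound 2 `O=S(=O)(NCCCNc1nccc(-c2c(-c3cccc(F)c3)nc3sccn23)n1)c1ccc(Br)cc1`: 7040 nM in this assay
compound 3 `Cc1ccc(S(=O)(=O)NCCNc2nccc(-c3c(-c4cccc(F)c4)nc4sccn34)n2)cc1`: 15400 nM in this assay

Compound 2 has the lowest of the three numbers in this assay, but its nearest neighbour is compound 1, with a 1.9-fold lower number from compound 1 to compound 2 (0.29 log units; within the scatter), a gap that stays within the scatter; only compound 3 sits beyond the scatter from it, with a 2.2-fold higher number from compound 2 to compound 3 (0.34 log units; beyond the scatter).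

Compound 4 `O=C(NCCNc1nccc(-c2c(-c3cccc(F)c3)nc3sccn23)n1)c1ccc(Cl)cc1` is not yet measured. Its change from compound 2 is ((4-chlorophenyl)carbonyl)amino in place of (((4-bromophenyl)sulfonyl)amino)methyl on a saturated chain carbon, two bonds along the chain from a nitrogen on an aromatic ring.

Within the data shown here, no measured step reproduces this change. The closest bearing is the step from compound 2 to compound 3, which also shortens the chain by one carbon and swaps the aryl on the sulfonyl sulfur, and gave a 2.2-fold higher number from compound 2 to compound 3 (0.34 log units; beyond the scatter), a modest rise. The step from compound 1 to compound 2, an aryl swap alone, gave a 1.9-fold lower number from compound 1 to compound 2 (0.29 log units; within the scatter), within the scatter. Among the measured compounds shown here, the exchange of sulfonyl for carbonyl has no precedent here, so the expectation rests on the chain-shortening precedent: a small rise in the number, at the edge of the scatter.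

Compound 4 is therefore expected near 11000 nM, with a range of 4500 nM to 27000 nM, and the estimated step from compound 2 is a 1.6-fold higher number from compound 2 to compound 4 (0.19 log units; within the scatter).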

Compound 4, half-maximal inhibitory concentration: 2570 nM
Beside the measured number, compound 4's estimate is 4.3-fold (0.63 log units) above it, outside the stated range (below it).
By their numbers in this assay, from the lowest: compound 4; then compounds 2, 1 and 3 (each within the scatter of the next, the first and the last beyond it).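

At the saturated chain carbon two bonds along the chain from a nitrogen on an aromatic ring, ((4-chlorophenyl)carbonyl)amino gives the lowest number of the series in this assay, with a 2.7-fold lower number from compound 2 to compound 4 (0.44 log units; beyond the scatter) and a 5.3-fold lower number from compound 1 to compound 4 (0.73 log units; beyond the scatter). Among these compounds, the closest comparison keeps the chain and places (4-chlorophenyl)carbonyl where (4-methylphenyl)sulfonyl stood on the amine nitrogen, giving a 6.0-fold lower number from compound 3 to compound 4 (0.78 log units; beyond the scatter); no step among the sulfonyl compounds, compound 1, compound 2 and compound 3, reached that size, so the first departure from the sulfonyl link also gives the first clear drop in the number. No measurement offered here accounts for this drop.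

The link and the aryl substituent change together in every step to compound 4, so a (4-methylphenyl)carbonyl group on the same chain would be needed to separate their contributions. A longer chain carrying the (4-chlorophenyl)carbonyl group, or a urea in place of the carbonyl amide, would show whether the lower number holds beyond this single compound.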